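Amide methyl shift on the cyclohexyl ring

A few compounds are considered here, and "the series" means these few. Any claim that something is new, unique, unknown or untested is made for them only; others in the source may bear on it.

- Compound 1 `C[C@H]1CCCC[C@H]1NC(=O)c1cc2c(Cl)cc(Cl)cc2[nH]1` gives < 4000 nM in a physicochemical assay for solubility, measured as thermodynamic solubility, with a stated time of 24 h, at pH 6.8; a lower number here means a less soluble compound, a higher number a more soluble compound (a limit)
- Compound 2 `[C-]#[N+]c1cc(C#N)c2cc(C(=O)NC3CCC(C)CC3)[nH]c2c1` gives < 4000 nM in this assay (a limit)

Both compounds sit at the limit of < 4000 nM in this assay, at which 2 of the 2 values shown sit, and neither gives a number, so compound 1 has no exact position. Compound 3 `C[C@H]1CC[C@@H](NC(=O)c2cc3c(Cl)cc(Cl)cc3[nH]2)CC1` keeps the core of compound 1 and carries 4-methylcyclohexyl in place of 2-methylcyclohexyl on an amide-type nitrogen. Going by the values given here, no measured step covers this change. No step beyond the scatter is expected in this assay and a further limit is the likely outcome. Among the compounds with values here, the expected step is a step that the limit leaves unreadable from compound 1 to compound 3 and rests on no measured pair. For compound 3 the estimate is 2500 nM with an expected range from 800 nM to 4000 nM in the same assay.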

Compound 3, solubility: < 4000 nM
Compound 3: no number, only a limit; the forecaster's own chance of this, stated with the estimate: 85%; the middle value is on the limit's open side.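

No step from compound 1 to compound 3 can be read in this assay, because both values are limits: the limit of < 4000 nM in this assay, at which 3 of the 3 values shown sit.

The compounds shown leave open whether 4-methylcyclohexyl in place of 2-methylcyclohexyl on an amide-type nitrogen changes solubility at all.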